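Swapping the ring substituent on the shared core

A few compounds are considered here, and "the series" means these few. Any claim that something is new, unique, unknown or untested is made for them only; others in the source may bear on it.

Measured compounds:
Compound 1, `Nc1scc(CN2CCN(c3cc(Cl)cc(Cl)c3)CC2)c1C(=O)c1ccc(Cl)cc1`: -1%
Compound 2, `Nc1scc(CN2CCN(c3ccc([N+](=O)[O-])cc3)CC2)c1C(=O)c1ccc(Cl)cc1`: -12%
Compound 3, `Nc1scc(CN2CCN(C3CCCCCC3)CC2)c1C(=O)c1ccc(Cl)cc1`: 2.9%

Three compounds sharing one core, and differing only in the group on the amine nitrogen in a ring, were tested in a functional assay on CHO cells with adenosine receptor A1 (Homo sapiens) as the target, read by cAMP accumulation and immunoassay, with a stated time of 6 min, tested at 0.01 uM; a higher number here means a weaker effect of the compound at the concentration tested, a lower number a stronger effect. All three numbers are small. Compound 3 stands above compound 2 by a number 14.9 percentage points higher from compound 2 to compound 3 (beyond the scatter), while its gap to compound 1, a number 3.9 percentage points higher from compound 1 to compound 3 (within the scatter), lies within the scatter. The step of a number 11 percentage points lower from compound 1 to compound 2 (beyond the scatter) is the only other difference beyond the scatter.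

Compound 4, `Nc1scc(CN2CCN(c3c(F)cccc3F)CC2)c1C(=O)c1ccc(Cl)cc1`, has not yet been measured. It differs from compound 3 in one place: 2,6-difluorophenyl in place of cycloheptyl on an amine nitrogen in a ring. Among the measured compounds shown here, the steps that bear on this are the two earlier exchanges at the same place, a number 3.9 percentage points higher from compound 1 to compound 3 (within the scatter) and a number 14.9 percentage points higher from compound 2 to compound 3 (beyond the scatter), which both return from an aryl group to cycloheptyl; compound 4 goes the other way, to a new aryl group. Those steps were small or within the scatter, and the three measured numbers all sit near zero, so no step beyond the scatter is expected for a number 2.9 percentage points lower from compound 3 to compound 4 (within the scatter). Compound 4 is therefore estimated to give 0%, with a range from -12% to 10%.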

Compound 4, a percentage reported as activity, at one concentration (the size of the read-out at that concentration, not a potency): -12%
Beside the measured number, compound 4's estimate is 12 percentage points above it; the measured number falls inside the stated range.
By their numbers in this assay, from the lowest: compounds 2 and 4 (each within the scatter of the next); then compounds 1 and 3 (each within the scatter of the next).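

In this assay, 2,6-difluorophenyl separates from cycloheptyl at this amine nitrogen (a number 14.9 percentage points lower from compound 3 to compound 4 (beyond the scatter)), while it cannot be told apart from 4-nitrophenyl (no change at the digits printed from compound 2 to compound 4 (within the scatter)). Two quite differently substituted phenyl rings therefore now read alike, yet a phenyl ring alone does not set the number: 2,6-difluorophenyl also separates from 3,5-dichlorophenyl (a number 11 percentage points lower from compound 1 to compound 4 (beyond the scatter)), and compound 1, with that dichlorinated ring, stays close to the non-aromatic cycloheptyl of compound 3 (a number 3.9 percentage points higher from compound 1 to compound 3 (within the scatter)). So the exchange of one ring for another matters here only for some pairs, and nothing measured alongside these numbers explains which pairs or why.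

On these data alone, it remains open whether an unsubstituted phenyl, a 4-fluorophenyl or an open chain such as butyl on this nitrogen would read like compounds 2 and 4 or like compounds 1 and 3. All of these numbers also come from a single concentration, so they show only a stronger or weaker effect at that concentration.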